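This account rests on a few compounds, and the source may have more. Where it says the series, first, only, none or still open, it means among the compounds named here.

Compound 1 `CNC(=O)c1cc(C(=O)NC2CC2)cn(Cc2ccc(C)cc2)c1=O` is the starting point of this comparison. Within the data shown here, in a physicochemical assay for solubility (a lower number here means a less soluble compound, a higher number a more soluble compound), compound 1 gives 24 ug/mL, which is the only plain number among the two measured compounds. Compound 2 `CNC(=O)c1cc(C(=O)NC2CCC2)cn(Cc2ccccn2)c1=O` is reported in this assay only as a limit, >= 103 ug/mL, and so it sits at the limit of >= 103 ug/mL in this assay, at which 1 of the 2 values shown sits, rather than at a number. Compound 3 `CNC(=O)c1cc(C(=O)NC2CC2)cn(Cc2cccc3[nH]ncc23)c1=O` has not yet been measured in this assay. It differs from compound 1 in one place: 1H-indazol-4-yl in place of 4-methylphenyl on a saturated chain carbon bound to an aromatic nitrogen. Among the measured compounds shown here, no measured pair differs in that way, so the size of this step cannot be read from the data. The step that the estimate below means, a 1.7-fold higher number from compound 1 to compound 3 (0.22 log units; within the scatter), is expected to be small and toward greater solubility, not clearly beyond the usual scatter. For compound 3 the expected solubility in this assay is 40 ug/mL, within a range from 15 ug/mL to 110 ug/mL.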

Compound 3, solubility: 10 ug/mL
Compound 3: the middle estimate sits 4.0-fold (0.60 log units) above what was measured; measured number outside the range, below it.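

Replacing 4-methylphenyl with 1H-indazol-4-yl on a saturated chain carbon bound to an aromatic nitrogen gives a 2.4-fold lower number from compound 1 to compound 3 (0.38 log units; beyond the scatter) in this assay. Among these compounds, this is the first single-place change that can be read here, and it shows that the group at this position can move the number, although only modestly: the two-ring group with a hydrogen-bond donor and a hydrogen-bond acceptor goes with the lower value. Compound 2 differs from compound 1 and compound 3 in more than one place, and nothing given here bears on why the step runs in this direction.

Going by these compounds, with one readable step, it remains open whether this direction is specific to 1H-indazol-4-yl or would hold for other groups at this position. An amine or a carboxylic acid at the same place could move the number either way.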